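This account rests on a few compounds, and the source may have more. Where it says the series, first, only, none or still open, it means among the compounds named here.

Values measured so far in an ADME assay on Akata cells (Homo sapiens) for cytotoxicity, with a stated time of 7 days; a lower number here means that less compound is tolerated, a higher number that more compound is tolerated:

- compound 1 `CNc1nc(N)nc2c1ncn2/C=C1/CC1(CO)CO`: > 24000 nM
- compound 2 `CCCNc1nc(N)nc2c1ncn2/C=C1/CC1(CO)CO`: > 24000 nM

Both entries are limits of the assay, not numbers. Going by these compounds, compound 2 has only its limit of > 24000 nM in this assay, so its true position is unknown. Among the compounds with values here, the same holds across the series so far: the limit of > 24000 nM in this assay, at which 2 of the 2 values shown sit.

Compound 3 `CCCCCCCCSc1nc(N)nc2c1ncn2/C=C1/CC1(CO)CO` has not yet been measured. It carries octylsulfanyl in place of propylamino on an aromatic carbon, on the shared core: octylsulfanyl in place of propylamino on an aromatic carbon.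

Within the data shown here, only one measured step bears on this change, a step that the two limits leave unreadable from compound 1 to compound 2. It gives no size to carry over, and it does not involve a change of the atom attached to the aromatic carbon. The expectation therefore rests on the structural change alone, and it is weak. Among the measured compounds shown here, since this exchange is much larger by count than the one between compound 1 and compound 2, a move towards less compound tolerated is tentatively expected, although another limit remains quite possible. The expected step is an at least 2.0-fold lower number from compound 2 to compound 3 (0.30 log units; that floor lies within the scatter). For compound 3 the estimate is 12000 nM, with an expected range from 3000 nM to 30000 nM.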

Compound 3, half-maximal cytotoxic concentration: > 20000 nM
Compound 3 gave a limit, no number; the forecaster's own chance of this, stated with the estimate: 45%; middle value at least 1.6-fold (0.22 log units) from the limit.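

In this assay compound 3 gives > 20000 nM, a limit of the assay and not a number. The steps from compound 1 and compound 2 to compound 3 therefore cannot be read. The compounds shown leave open where the true half-maximal cytotoxic concentration of each lies, and whether octylsulfanyl in place of propylamino on an aromatic carbon changes it at all.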